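The source may report more compounds than this note shows. Statements on the series, on what has been measured and on what is new or still open speak of the compounds shown alone.

Three chalcone-like compounds sharing one core have been measured in a functional assay on A549 cells (Homo sapiens) for antiproliferative activity, read by XTT assay, with a stated time of 72 h; on this read-out higher numbers stand for weaker inhibition and lower numbers for stronger inhibition. Compound 1 `COc1ccc(C(=O)/C=C/c2nc3ccccc3cc2-c2ccc(OC)cc2)cc1` gives 8500 nM, compound 2 `COc1ccc(-c2cc3ccccc3nc2/C=C/C(=O)c2ccc(OC)cc2OC)cc1` gives 7990 nM, and compound 3 `COc1ccc(-c2cc3ccccc3nc2/C=C/C(=O)c2ccc([N+](=O)[O-])cc2)cc1` gives 6310 nM. Compound 3 has the lowest of the three numbers, but the step of a 1.3-fold lower number from compound 2 to compound 3 (0.10 log units; within the scatter) and the step of a 1.3-fold lower number from compound 1 to compound 3 (0.13 log units; within the scatter) both stay within the scatter, so the three compounds cannot be ranked. Compound 4 `COc1ccc(-c2cc3ccccc3nc2/C=C/C(=O)c2ccc(Br)s2)cc1` is not yet measured; its change from compound 3 is 5-bromothiophen-2-yl in place of 4-nitrophenyl on a carbonyl carbon. Within the data shown here, only the step from compound 2 to compound 3 concerns the same carbonyl carbon, and it was small, so no step beyond the scatter is expected in this assay. Compound 4 is estimated at 6000 nM, between 2000 nM and 18000 nM, an expected step of a 1.1-fold lower number from compound 3 to compound 4 (0.02 log units; within the scatter).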

Compound 4, half-maximal inhibitory concentration: 6250 nM
Estimate against measurement, compound 4: 1.0-fold (0.02 log units) below; the range from low to high includes it.
By their numbers in this assay, from the lowest: compounds 4, 3, 2 and 1 (each within the scatter of the next).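

In this assay the carbonyl carbon accepts a five-membered sulfur ring carrying bromine as readily as the six-membered rings seen so far: the steps are a 1.0-fold lower number from compound 3 to compound 4 (0.00 log units; within the scatter) and a 1.3-fold lower number from compound 2 to compound 4 (0.11 log units; within the scatter) and a 1.4-fold lower number from compound 1 to compound 4 (0.13 log units; within the scatter), so all four compounds remain unranked. A smaller group of a different ring type thus leaves the number within the scatter. Nothing available here bears on the reason for this. Still open, on these data alone, is whether a non-aromatic group on this carbon, such as an amine or a carboxylic acid, would give a step beyond the scatter. Changes to the shared core also remain open.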